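A few compounds are considered here, and "the series" means these few. Any claim that something is new, unique, unknown or untested is made for them only; others in the source may bear on it.

Measured so far:
compound 1 `CC1=C(/C=C/C(=O)/C=C/c2ccccc2)C(C)(C)CCC1O`: 8000 nM
compound 2 `CC1=C(/C=C/C(=O)/C=C/c2cccc(C(F)(F)F)c2)C(C)(C)CCC1O`: 1700 nM

In a functional assay on CWR22R cells (Homo sapiens) for cytotoxicity, read by MTT assay, with a stated time of 72 h (a lower number here means a stronger inhibitor, a higher number a weaker inhibitor), compound 2 stands lowest of the two numbers; its nearest neighbour is compound 1 with 8000 nM. Compound 3 `CC1=C(/C=C/C(=O)/C=C/c2cc(C(F)(F)F)cc(C(F)(F)F)c2)C(C)(C)CCC1O` differs from compound 2 by trifluoromethyl in place of hydrogen on an aromatic carbon. Among the compounds with values here, the one measured step that bears on this change is a 4.7-fold lower number from compound 1 to compound 2 (0.67 log units; beyond the scatter). A second group of the same kind is expected to move the number in the same direction but less, an estimated 1.7-fold lower number from compound 2 to compound 3 (0.23 log units; within the scatter) in this assay. Compound 3 is therefore expected to give about 1000 nM, within a range of 400 nM to 3000 nM.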

Compound 3, half-maximal inhibitory concentration: 2200 nM
Estimate against measurement, compound 3: 2.2-fold (0.34 log units) below; low and high end bracket the measured number.
By their numbers in this assay, from the lowest: compounds 2 and 3 (each within the scatter of the next); then compound 1.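

In this assay the first trifluoromethyl group moved the number beyond the scatter, but a second one, meta to a trifluoromethyl group, does not: the change is a 1.3-fold higher number from compound 2 to compound 3 (0.11 log units; within the scatter). On this aromatic ring, then, the effect of the first group does not repeat with the second, and compound 2 and compound 3 cannot be told apart in this cell assay. Nothing available accounts for this result. The compounds shown leave open whether an amine or a carboxylic acid at this position would move the number. They also leave open whether replacing the hydroxyl group on the shared core would do so.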